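The compounds below may be only part of what the source reports. "The series", "measured", "known", "first", "only" and "open" are said of these compounds alone.

Measured in an ADME assay on HepG2 cells (Homo sapiens) for cytotoxicity, read by MTT assay, with a stated time of 48 h; on this read-out higher numbers stand for lower toxicity in this test and lower numbers for higher toxicity in this test:
- compound 1 `CC(=O)OC[C@H]1O[C@H](OC[C@H](Cn2cc(COc3ccc(-c4noc(NC5CCCCC5)n4)cc3)nn2)OC(C)=O)C=C[C@@H]1OC(C)=O`: 99.5 ug/mL
- compound 2 `C#CCOc1ccc(-c2noc(N(CC#C)C3CCCCC3)n2)cc1`: > 200 ug/mL (a limit, not a number)
- compound 3 `C#CCOc1ccc(-c2noc(NC3CCCCC3)n2)cc1`: 119 ug/mL

Compound 2 has no number on this read-out, only a limit, so its position is known from one side alone. The relevant entry is the limit of > 200 ug/mL in this assay, at which 1 of the 3 values shown sits.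

Still to be measured is compound 4 `C#CCN(c1nc(-c2ccc(C(F)(F)F)cc2)no1)C1CCCCC1`, which departs from compound 2 as follows: trifluoromethyl in place of propargyloxy on an aromatic carbon. In words, trifluoromethyl stands in place of propargyloxy on an aromatic carbon, para to a large group.

Going by the values given here, no measured step covers this exchange. The only one available, an at least 1.6-fold lower number from compound 2 to compound 3 (0.22 log units; that floor lies within the scatter), puts hydrogen in place of propargyl on a nitrogen, a different site, and its floor lies within the scatter. Compound 3 gives 119 ug/mL and compound 1 gives 99.5 ug/mL, two values within the scatter of each other.

Among the compounds with values here, with no measured step to give a size or direction in this assay, no step beyond the scatter is expected. The expected change is an at least 1.1-fold lower number from compound 2 to compound 4 (0.04 log units; that floor lies within the scatter). For compound 4 the estimated value is 180 ug/mL, with an expected range from 90 ug/mL to 300 ug/mL.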

Compound 4, half-maximal cytotoxic concentration: 61.9 ug/mL
The estimate for compound 4 lay 2.9-fold (0.46 log units) above the measured number; the whole stated range lies above it.
By their numbers in this assay, from the lowest: compounds 4, 1 and 3 (each within the scatter of the next). At a limit, above all of these: compound 2.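

In this assay, trifluoromethyl in place of propargyloxy on an aromatic carbon, para to a large group, gives an at least 3.2-fold lower number from compound 2 to compound 4 (0.50 log units; beyond the scatter). The only earlier step, an at least 1.6-fold lower number from compound 2 to compound 3 (0.22 log units; that floor lies within the scatter), sits at a different site and has a floor within the scatter, so this aromatic carbon is the first site in the series where a single exchange is shown to lower the number beyond the scatter, towards higher toxicity in this test. The true size of the step remains unknown, and its figure is only a floor, because compound 2 carries a limit and not a number: the limit of > 200 ug/mL in this assay, at which 1 of the 4 values shown sits.

The compounds shown do not separate the loss of propargyloxy from the entry of trifluoromethyl, and a methoxy group or a plain hydrogen on this aromatic carbon would bear directly on that question. Also open, as far as these compounds go, is whether the same exchange gives a step of similar size when the nitrogen carries hydrogen, as in compound 3, in place of propargyl.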